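A few compounds are considered here, and "the series" means these few. Any claim that something is new, unique, unknown or untested is made for them only; others in the source may bear on it.

Measured compounds in an assay on TT cells for inhibition of proto-oncogene tyrosine-protein kinase receptor Ret variant C634W (Homo sapiens), read by MTT assay, with a stated time of 10 days; a higher number here means a weaker inhibitor of growth, a lower number a stronger inhibitor of growth:
- compound 1, `CC(C)n1nc(-c2cc(-c3ccccc3)on2)c2c(N)ncnc21`: > 10000 nM
- compound 2, `CCc1cc(-c2nn(C(C)C)c3ncnc(N)c23)no1`: 2610 nM
- compound 3, `CC(C)n1nc(-c2cc(-c3ccc(F)cc3)on2)c2c(N)ncnc21`: > 10000 nM

Compound 3 gives only a limit of the assay in this assay, with no number behind it. The value of compound 1 in this assay is likewise a limit, and the limit of > 10000 nM in this assay, at which 2 of the 3 values shown sit, marks where both sit. Compound 2 is the only one of the three with a read number in this assay.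

Compound 4, `CC(C)c1cc(-c2nn(C(C)C)c3ncnc(N)c23)no1`, differs from compound 3 at a single place: isopropyl in place of 4-fluorophenyl on an aromatic carbon.

The step from compound 3 to compound 4 therefore swaps the aryl group for a small alkyl chain, and two measured steps bear on it. The change from compound 1 to compound 2 did the comparable thing with a smaller chain and gave an at least 3.8-fold lower number from compound 1 to compound 2 (0.58 log units; beyond the scatter), while the reverse direction is seen in an at least 3.8-fold higher number from compound 2 to compound 3 (0.58 log units; beyond the scatter). The step from compound 1 to compound 3 is a step that the two limits leave unreadable from compound 1 to compound 3. Compound 4 is therefore expected to behave like compound 2 rather than like compound 3, with a step of an at least 3.3-fold lower number from compound 3 to compound 4 (0.52 log units; beyond the scatter) that is expected to move the number downward and beyond the scatter. The estimate for compound 4 in this assay is 3000 nM, with a range from 1000 nM to 10000 nM, and this is expected rather than known.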

Compound 4, concentration for 50% growth inhibition: 5130 nM
The estimate for compound 4 lay 1.7-fold (0.23 log units) below the measured number; measured number inside the range.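

In this assay, compound 4 shows that a read number at this position is not confined to the ethyl of compound 2: isopropyl on the aromatic carbon next to the ring oxygen also gives one, and the added methyl on that chain gives a 2.0-fold higher number from compound 2 to compound 4 (0.29 log units; within the scatter), so the two chains cannot be told apart. Set against the two aryl compounds, the change gives an at least 1.9-fold lower number from compound 3 to compound 4 (0.28 log units; that floor lies within the scatter) and an at least 1.9-fold lower number from compound 1 to compound 4 (0.28 log units; that floor lies within the scatter); both are floors only, so the true gaps may be larger, but as printed neither floor clears the scatter. Compound 1 and compound 3 each give a limit of the assay rather than a number: the limit of > 10000 nM in this assay, at which 2 of the 4 values shown sit.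

The compounds shown leave open whether a cyclopropyl or a tert-butyl group at this carbon would keep a read number, and whether a chain ending in an amine or a hydroxyl group would bring the number below that of compound 2. They also leave open whether the number follows chain length at all, as ethyl and isopropyl are the only chains here and they lie within the scatter of each other.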